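Replacing the (tert-butyl)carbonyl of compound 3 with cyclohexylsulfonyl

The source may hold more compounds than are shown below. What is called first, only, known or untested is meant among the compounds shown, and "the series" means these compounds.

In a functional assay on HeLa cells (Homo sapiens) for antiproliferative activity, read by MTT assay, with a stated time of 48 h (a lower number here means a stronger inhibitor, a higher number a weaker inhibitor), compound 3 (`COc1ccc(-c2cn3cc(C4=CCN(C(=O)C(C)(C)C)CC4)ccc3n2)cc1OC`) gives 5480 nM and sits within the scatter of compound 1 (`COc1ccc(-c2cn3cc(C4=CCN(S(=O)(=O)CCc5ccccc5)CC4)ccc3n2)cc1OC`) at 8980 nM. Compound 2 (`COc1ccc(-c2cn3cc(C4=CCN(C(=O)c5ccc(Cl)cc5)CC4)ccc3n2)cc1OC`) gives 12200 nM in this small set, and the gap between it and compound 3 lies beyond the scatter. Compound 4 (`COc1ccc(-c2cn3cc(C4=CCN(S(=O)(=O)C5CCCCC5)CC4)ccc3n2)cc1OC`) carries cyclohexylsulfonyl in place of (tert-butyl)carbonyl on an amine nitrogen in a ring and has not yet been measured. Within the data shown here, the nearest guide is a 1.6-fold lower number from compound 1 to compound 3 (0.21 log units; within the scatter) which joins the only measured sulfonyl compound to the same (tert-butyl)carbonyl. Beside it, a 1.4-fold higher number from compound 1 to compound 2 (0.13 log units; within the scatter) likewise shows a sulfonyl and a carbonyl compound staying close. The remaining step, a 2.2-fold lower number from compound 2 to compound 3 (0.35 log units; beyond the scatter) changes only the group on the carbonyl carbon and so bears less directly. A small rise at most is therefore expected, and the estimated step in this assay is a 1.3-fold higher number from compound 3 to compound 4 (0.11 log units; within the scatter) with no clear change beyond the scatter anticipated. For compound 4 the expected value is 7000 nM (estimated range 3500 nM to 14000 nM).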

Compound 4, half-maximal inhibitory concentration: 9990 nM
Compound 4: middle estimate off by 1.4-fold (0.15 log units), on the low side; measured number inside the range.
By their numbers in this assay, from the lowest: compounds 3, 1, 4 and 2 (each within the scatter of the next, the first and the last beyond it).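

In this assay, cyclohexylsulfonyl on the amine nitrogen in the ring stays within the scatter of all three earlier groups, with a 1.8-fold higher number from compound 3 to compound 4 (0.26 log units; within the scatter), a 1.2-fold lower number from compound 2 to compound 4 (0.09 log units; within the scatter) and a 1.1-fold higher number from compound 1 to compound 4 (0.05 log units; within the scatter). Among these compounds, the last of these is the first step in the set that changes the group on a sulfonyl sulfur, and cyclohexyl in place of phenethyl there does not separate the two sulfonyl compounds, while compound 4 also lies within the scatter of both compound 2 and compound 3, the one pair set apart beyond it. Nothing measured here accounts for these numbers.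

Still open, from the compounds shown here alone, is how cyclohexylcarbonyl would compare with cyclohexylsulfonyl, a pairing that would isolate the carbonyl-to-sulfonyl change with the cyclohexyl group held constant. Going by these compounds, it is also open whether a free amine on that nitrogen, or a carboxylic acid on the attached chain, would move the number beyond the scatter.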